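The source may report more compounds than this note shows. Statements on the series, on what has been measured and on what is new or still open speak of the compounds shown alone.

Of the compounds shown here, three on one shared core have been measured so far in an ADME assay on MT4 cells (Homo sapiens) for cytotoxicity, read by MTT assay (on this read-out higher numbers stand for lower toxicity in this test and lower numbers for higher toxicity in this test), and they give a first picture. Compound 1 `O=C1c2ccccc2C(=O)N1CCOC(=S)N(C(=O)c1cccc(F)c1F)c1ccc(Cl)cc1` gives 58000 nM and compound 2 `O=C1c2ccccc2C(=O)N1CCOC(=S)N(C(=O)c1cc(F)cc(F)c1)c1ccc(Cl)cc1` gives 59000 nM in this test. Exchanging one difluorophenyl group for the other gave a 1.0-fold higher number from compound 1 to compound 2 (0.01 log units; within the scatter) and so no real change. Compound 3 `O=C1c2ccccc2C(=O)N1CCOC(=S)N(C(=O)c1ccc(Cl)cc1Cl)c1ccc(Cl)cc1` has the lowest number of the three at 18000 nM and so the highest toxicity in this test. Two modest steps lead there, a 3.2-fold lower number from compound 1 to compound 3 (0.51 log units; beyond the scatter) and a 3.3-fold lower number from compound 2 to compound 3 (0.52 log units; beyond the scatter) with a 2,4-dichlorophenyl group replacing a difluorophenyl group each time.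

Compound 4 `O=C1c2ccccc2C(=O)N1CCOC(=S)N(C(=O)c1ccc(Cl)c(Cl)c1)c1ccc(Cl)cc1` is still unmeasured and differs from compound 3 like this: 3,4-dichlorophenyl in place of 2,4-dichlorophenyl on a carbonyl carbon with 3,4-dichlorophenyl in place of 2,4-dichlorophenyl on a carbonyl carbon. Among the measured compounds shown here, no measured step compares two dichlorophenyl groups directly. The nearest guide is the exchange between difluorophenyl groups, a 1.0-fold higher number from compound 1 to compound 2 (0.01 log units; within the scatter) which stayed within the scatter. No step beyond the scatter is therefore expected in this assay and the estimated step is a 1.2-fold higher number from compound 3 to compound 4 (0.07 log units; within the scatter) as a best guess. For compound 4 the estimated value is 21000 nM with an expected range of 9000 nM to 50000 nM in this test.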

Compound 4, half-maximal cytotoxic concentration: 35000 nM
Compound 4: middle estimate off by 1.7-fold (0.22 log units), on the low side, and the stated range covers the measured number.
By their numbers in this assay, from the lowest: compounds 3, 4, 1 and 2 (each within the scatter of the next, the first and the last beyond it).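

Exchanging 2,4-dichlorophenyl for 3,4-dichlorophenyl on a carbonyl carbon keeps the same atoms but joins them differently, and it gives a 1.9-fold higher number from compound 3 to compound 4 (0.29 log units; within the scatter) in this assay, so this exchange does not clearly separate the two dichlorophenyl groups. The difluorophenyl comparisons also stay within the scatter, with a 1.7-fold lower number from compound 1 to compound 4 (0.22 log units; within the scatter) and a 1.7-fold lower number from compound 2 to compound 4 (0.23 log units; within the scatter), so compound 4 goes against any idea that a dichlorophenyl group at this place always lowers the number; only compound 3 lies beyond the scatter from compounds 1 and 2. Nothing available explains these numbers.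

Every group shown at this place is a phenyl ring carrying two fluorine or two chlorine atoms. On these data alone, how a methoxy group, a carboxylic acid or an unsubstituted phenyl ring would read here remains open.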